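Removing the acetyl group from compound 2

A few compounds are considered here, and "the series" means these few. Any claim that something is new, unique, unknown or untested is made for them only; others in the source may bear on it.

Measured so far in a functional assay on NCI-H1581 cells (Homo sapiens) for antiproliferative activity, read by CCK-8 assay, with a stated time of 72 h; a lower number here means a stronger inhibitor, a higher number a weaker inhibitor:
- compound 1 `COc1cc(OC)c(Cl)c(-c2ccc3c(NC(=O)c4ccc(N5CCCCC5)cc4)n[nH]c3n2)c1Cl`: 558 nM
- compound 2 `COc1cc(OC)c(Cl)c(-c2ccc3c(NC(=O)c4ccc(N5CCN(C(C)=O)CC5)cc4)n[nH]c3n2)c1Cl`: 43.3 nM
- compound 3 `COc1cc(OC)c(Cl)c(-c2ccc3c(NC(=O)c4ccc(N5CCN(C)CC5)cc4)n[nH]c3c2)c1Cl`: 324 nM

Compound 2 has the lowest of the three numbers, which makes it the strongest inhibitor here. Compound 4 `COc1cc(OC)c(Cl)c(-c2ccc3c(NC(=O)c4ccc(N5CCNCC5)cc4)n[nH]c3n2)c1Cl` differs from it in one place: hydrogen in place of acetyl on an amine nitrogen in a ring. Among the compounds with values here, the only measured step touching this group is a 13-fold lower number from compound 1 to compound 2 (1.11 log units; beyond the scatter). It shows that a change here can move the number a lot, but it swaps a whole ring group, so it is a loose guide. Within the data shown here, compound 3 has a different core, and no single step links it to compound 2. A modest move towards a higher number is therefore expected in this assay. The estimated step is a 1.8-fold higher number from compound 2 to compound 4 (0.27 log units; within the scatter). Compound 4 is expected at 80 nM, with an estimated range of 20 nM to 320 nM.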

Compound 4, half-maximal inhibitory concentration: 1.4 nM
Beside the measured number, compound 4's estimate is 57-fold (1.76 log units) above it, outside the stated range (below it).
By their numbers in this assay, from the lowest: compound 4; then compound 2; then compounds 3 and 1 (each within the scatter of the next).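

In this assay the acetyl on the ring nitrogen proves costly, since removing it gives a far lower number (a 31-fold lower number from compound 2 to compound 4 (1.49 log units; beyond the scatter)). The piperazin-1-yl group carrying only hydrogen on that nitrogen also far outdoes piperidin-1-yl (a 400-fold lower number from compound 1 to compound 4 (2.60 log units; beyond the scatter)), so the step from compound 1 to compound 2 captured only part of what this nitrogen can give. Nothing available explains the size of these steps. On these data alone, whether an ethyl group or a longer chain on that nitrogen would keep the number this low remains open. Compound 3 carries methyl there, but on a different core, so it cannot settle this.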